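A few compounds are considered here, and "the series" means these few. Any claim that something is new, unique, unknown or untested is made for them only; others in the source may bear on it.

Measured compounds in a functional assay on CCRF-CEM cells (Homo sapiens) for cytotoxicity, read by cell counting, with a stated time of 3 days; on this read-out higher numbers stand for weaker inhibition and lower numbers for stronger inhibition:

Compound 1 `C=C(Br)C(=O)Nc1ccc(/C=C2\SC(=O)N(CC)C2=O)cc1` gives 870 nM.
Compound 2 `C=C(Br)C(=O)Nc1cccc(/C=C2\SC(=O)N(Cc3cccc(F)c3)C2=O)c1` gives 690 nM.
Compound 3 `Cc1ccc(CN2C(=O)S/C(=C\c3cccc(N)c3)C2=O)cc1` gives only a limit of the assay, > 250000 nM.

Among the two compounds that give an actual number in this assay, compound 2 and compound 1 sit within the usual scatter of one another, so neither can be said to inhibit more strongly than the other. For compound 3 the assay gives no number at all, only (the limit of > 250000 nM in this assay, at which 1 of the 3 values shown sits), so it cannot be placed beside the other two.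

Compound 4 `C=C(Br)C(=O)Nc1cccc(/C=C2\SC(=O)N(Cc3ccc(F)cc3)C2=O)c1` has not yet been measured. It differs from compound 2 in one place: 4-fluorophenyl in place of 3-fluorophenyl on a saturated chain carbon bound to an amide-type nitrogen in a ring. The two compounds share every atom and differ only in how the fluorine is placed on that ring. Going by the values given here, no pair of measured compounds here shows what such a move does, so there is no measured step to lean on. The expectation is that the change from compound 2 to compound 4 brings a step of no more than the scatter in this assay, in no firm direction, giving an expected 1.0-fold higher number from compound 2 to compound 4 (0.01 log units; within the scatter). Compound 4 is therefore estimated at 700 nM, with a range from 300 nM to 1800 nM.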

Compound 4, half-maximal inhibitory concentration: 680 nM
Estimate against measurement, compound 4: 1.0-fold (0.01 log units) above, within the range that was stated.
By their numbers in this assay, from the lowest: compounds 4, 2 and 1 (each within the scatter of the next). At a limit, above all of these: compound 3.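

In this assay, placing 4-fluorophenyl where 3-fluorophenyl stood, on a saturated chain carbon bound to an amide-type nitrogen in a ring, gives a 1.0-fold lower number from compound 2 to compound 4 (0.01 log units; within the scatter). Going by these compounds alone, this is the first measured step at this place, and it shows that, for this one pair, moving the fluorine around the ring leaves the read-out within the usual scatter, so compound 2 and compound 4 cannot be told apart here. Nothing measured here bears on why the read-out stays the same, and one pair sets no rule for other changes at this place.

From the compounds shown here alone, what this ring tolerates beyond a shift of the fluorine stays open: a plain phenyl ring with no fluorine, or one carrying a carboxylic acid or a dimethylamino group instead, could give a very different number. Compound 3 gives only a limit of the assay, > 250000 nM, and it differs from the other compounds in more than one place, so it cannot settle that question.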